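Swapping the amino group on the limit compound

The source may report more compounds than this note shows. Statements on the series, on what has been measured and on what is new or still open speak of the compounds shown alone.

In a functional assay on MCF7 cells (Homo sapiens) for antiproliferative activity, read by MTT assay, with a stated time of 72 h (on this read-out lower numbers stand for stronger inhibition and higher numbers for weaker inhibition), compound 3 `CCN(CC)c1cc(C)c2cc(NC(=O)c3ccc(Cl)c(Cl)c3)ccc2n1` gives > 50000 nM, which is a limit and not a number. Compound 4 `CCN(CC)CCNc1cc(C)c2cc(NC(=O)c3ccc(Cl)c(Cl)c3)ccc2n1` carries (2-(diethylamino)ethyl)amino in place of diethylamino on an aromatic carbon next to the ring nitrogen: (2-(diethylamino)ethyl)amino in place of diethylamino on an aromatic carbon. Compound 1 `CCN1CCN(c2cc(C)c3cc(NC(=O)c4ccc(C)cc4)ccc3n2)CC1` gives 6740 nM and compound 2 `CCN1CCN(c2cc(C)c3cc(NC(=O)c4cccc(Cl)c4)ccc3n2)CC1` gives 3820 nM, both with a different group on that carbon. Among the compounds with values here, the only measured step, a 1.8-fold lower number from compound 1 to compound 2 (0.25 log units; within the scatter), lies on the other side of the molecule and gives no direct size for this change. The guide is therefore indirect: compound 2 reads 3820 nM, a number rather than a limit. A move towards a lower number is expected, estimated as an at least 6.2-fold lower number from compound 3 to compound 4 (0.79 log units; beyond the scatter). Compound 4 is estimated at 8000 nM, with an expected range of 2000 nM to 35000 nM.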

Compound 4, half-maximal inhibitory concentration: 1420 nM
Estimate against measurement, compound 4: 5.6-fold (0.75 log units) above, and the stated range ends above it.
By their numbers in this assay, from the lowest: compound 4; then compounds 2 and 1 (each within the scatter of the next). At a limit, above all of these: compound 3.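

Replacing diethylamino with (2-(diethylamino)ethyl)amino on the aromatic carbon next to the ring nitrogen gives, in this assay, an at least 35-fold lower number from compound 3 to compound 4 (1.54 log units; beyond the scatter). Within the data shown here, this position therefore affects the read-out strongly, whereas the only earlier step lay on the carbonyl side and stayed within the scatter. The size of the new step is only a bound, since compound 3 stands at a limit and not at a number: the limit of > 50000 nM in this assay, at which 1 of the 4 values shown sits.

The change adds both a hydrogen-bond donor and a terminal diethylamino, and the compounds shown do not separate the two. Open too, as far as these compounds go, is how a simple ethylamino, or a longer chain ending in a hydroxyl group, would read at this position.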